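Swapping an ester for an ether on a chromone scaffold

A few compounds are considered here, and "the series" means these few. Any claim that something is new, unique, unknown or untested is made for them only; others in the source may bear on it.

Of the compounds shown here, two have been measured in a functional assay on A549 cells (Homo sapiens) for cytotoxicity, with a stated time of 48 h; on this read-out lower numbers stand for stronger inhibition and higher numbers for weaker inhibition. Compound 1 `CC(C)C(=O)Oc1ccc2oc(/C=C/[S+](C)[O-])cc(=O)c2c1` gives 2400 nM, and compound 2 `COc1cccc2oc(/C=C/[S+](C)[O-])cc(=O)c12` gives 3800 nM; these two numbers sit within the usual scatter of each other, so neither can be called more active. Compound 3 `CC(C)CCOc1ccc2oc(/C=C/[S+](C)[O-])cc(=O)c2c1` has not yet been measured. It differs from compound 1 in one place: isopentyl in place of isopropylcarbonyl on an oxygen on an aromatic ring. Among the compounds with values here, no measured pair shows such a change, so the step of a 1.0-fold higher number from compound 1 to compound 3 (0.02 log units; within the scatter) is expected to stay within the scatter. Compound 3 is therefore estimated at 2500 nM, with a range from 900 nM to 7000 nM.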

Compound 3, half-maximal inhibitory concentration: 1000 nM
Estimate against measurement, compound 3: 2.5-fold (0.40 log units) above; the range from low to high includes it.
By their numbers in this assay, from the lowest: compound 3; then compounds 1 and 2 (each within the scatter of the next).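

Attached to the oxygen on the aromatic ring, isopentyl in place of isopropylcarbonyl gives a 2.4-fold lower number from compound 1 to compound 3 (0.38 log units; beyond the scatter) in this assay. Within the data shown here, this is the first step here beyond the scatter, so activity in this assay does respond to the group at this position. The two groups have the same count of heavy atoms, but only isopropylcarbonyl has a carbonyl, and nothing available explains the difference.

As far as these compounds go, it remains open whether the loss of the carbonyl or the shape of the chain matters more. A straight pentyl chain, a shorter ethyl chain or a chain ending in an amine could help separate these possibilities.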